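A few compounds are considered here, and "the series" means these few. Any claim that something is new, unique, unknown or untested is made for them only; others in the source may bear on it.

In a functional assay on B16-F10 cells (Mus musculus) for antiproliferative activity, read by MTT assay, with a stated time of 48 h (on this read-out higher numbers stand for weaker inhibition and lower numbers for stronger inhibition), three compounds have been measured: compound 1 (`O=C(/C=C/c1ccc(O)c(O)c1)N1CCN(c2ccccc2F)CC1`) gives 2.43 ug/mL, compound 2 (`O=C(/C=C/c1ccc(O)c(O)c1)N1CCN(c2ccccc2Cl)CC1`) gives 1.82 ug/mL and compound 3 (`COc1ccccc1N1CCN(C(=O)/C=C/c2ccc(O)c(O)c2)CC1`) gives 1.23 ug/mL. Compound 3 stands within the usual scatter of both others, so the three cannot be ranked. Compound 4 (`O=C(/C=C/c1ccc(O)c(O)c1)N1CCN(c2ccc(Cl)c(Cl)c2)CC1`) has 3,4-dichlorophenyl in place of 2-methoxyphenyl on an amine nitrogen in a ring. Swapping the group on an aromatic carbon has so far given only small steps: a 1.3-fold lower number from compound 1 to compound 2 (0.13 log units; within the scatter), a 2.0-fold lower number from compound 1 to compound 3 (0.30 log units; within the scatter) and a 1.5-fold lower number from compound 2 to compound 3 (0.17 log units; within the scatter). For the measured compounds named here, no measured compound carries 3,4-dichlorophenyl, so this guide is loose. No step beyond the scatter is expected in this assay. The expected step is a 1.5-fold higher number from compound 3 to compound 4 (0.17 log units; within the scatter). For compound 4 the estimated value is 1.8 ug/mL, with an expected range from 0.8 ug/mL to 4 ug/mL.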

Compound 4, half-maximal inhibitory concentration: 1.66 ug/mL
Compound 4: the middle estimate sits 1.1-fold (0.04 log units) above what was measured; low and high end bracket the measured number.
By their numbers in this assay, from the lowest: compounds 3, 4, 2 and 1 (each within the scatter of the next).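

For the compounds shown here, putting 3,4-dichlorophenyl on the ring nitrogen replaces the whole substituted phenyl group, not only one group on an aromatic carbon, yet every step stays small: a 1.3-fold higher number from compound 3 to compound 4 (0.13 log units; within the scatter), a 1.1-fold lower number from compound 2 to compound 4 (0.04 log units; within the scatter) and a 1.5-fold lower number from compound 1 to compound 4 (0.17 log units; within the scatter). Among these four compounds, then, this larger change at this position separates nothing beyond the scatter. Nothing available explains why the numbers stay so close.

All four compounds keep a substituted phenyl on that nitrogen. Going by these compounds, whether a cyclohexyl or a plain methyl there, or a phenyl bearing a carboxylic acid, would move the number beyond the scatter remains open.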